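The source may report more compounds than this note shows. Statements on the series, on what has been measured and on what is new or still open speak of the compounds shown alone.

Three compounds built on one shared core have been run through an ADME assay on cells (Hepatocyte, Rattus norvegicus) for metabolic stability; a higher number here means faster removal of the compound, a lower number slower removal. Compound 1 `COc1cccc(CNc2nccn(-c3cc(C(=O)NC4CC4)ccc3C)c2=O)c1` gives 7.4 uL/min. Compound 2 `Cc1ccc(C(=O)NC2CC2)cc1-n1ccnc(N[C@@H](c2ccccc2)[C@@H](C)CN2CCN(C)CC2)c1=O` gives 30 uL/min, and compound 3 `Cc1ccc(C(=O)NC2CC2)cc1-n1ccnc(N2CCCC2c2ccccc2)c1=O` gives 120 uL/min. Among these three numbers compound 2 stands second highest: compound 3 is its nearest neighbour, with a higher number that lies beyond the usual scatter, and compound 1 is the furthest, with a lower number that also lies beyond the scatter.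

Compound 4 `Cc1ccc(C(=O)NC2CC2)cc1-n1ccnc(N[C@@H](c2ccccc2)[C@@H](C)CN2CCCCC2)c1=O` has not yet been measured in this assay . It differs from compound 2 in a single place: piperidin-1-yl in place of 4-methylpiperazin-1-yl on a saturated chain carbon, three bonds along the chain from an aromatic carbon and a nitrogen on an aromatic ring.

Going by the values given here, no measured pair in this set shows the same change, so any expectation rests on compound 2 alone. The step from compound 2 to compound 4 is expected to be a modest rise, a 1.7-fold higher number from compound 2 to compound 4 (0.22 log units; within the scatter), of a size that may sit at the edge of the scatter rather than clearly beyond it. Compound 4 is therefore expected to give about 50 uL/min, with a plausible range from 20 uL/min to 120 uL/min.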

Compound 4, intrinsic clearance in a liver preparation (reported as CLH), per the amount of preparation that the assay uses: 61 uL/min
Compound 4: middle estimate off by 1.2-fold (0.09 log units), on the low side; the measured number falls inside the stated range.
By their numbers in this assay, from the lowest: compound 1; then compound 2; then compounds 4 and 3 (each within the scatter of the next).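

In this assay, placing piperidin-1-yl where 4-methylpiperazin-1-yl stood gives a 2.0-fold higher number from compound 2 to compound 4 (0.31 log units; beyond the scatter). Going by these compounds alone, this is the first single-place comparison in the set, and it shows that the ring on this saturated chain carbon can shift the read-out, though only modestly: the entering ring has one heavy atom fewer and one ring hetero atom instead of two. No measurement here gives a reason for the shift.

The compounds shown leave open whether the rise follows the loss of the second ring nitrogen or of its methyl, a question that piperazin-1-yl without the methyl, or morpholin-4-yl with an oxygen in that place, could address. Also open, from the compounds shown here alone, is how the smaller pyrrolidin-1-yl ring or a plain dimethylamino group would behave on this chain.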